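Dropping the Fluoro Group from Compound 3

The compounds below may be only part of what the source reports. "The series", "measured", "known", "first", "only" and "open" are said of these compounds alone.

Compound 1 `COc1ccc(OC)c(/C=N/NC(=O)Nc2ccc(Oc3ccnc(-c4nncn4CCN(C)C)c3)c(F)c2)c1`: in a functional assay on U-87MG ATCC cells (Homo sapiens) for cytotoxicity, read by MTT assay, with a stated time of 72 h (a lower number here means a stronger inhibitor, a higher number a weaker inhibitor), compound 1 gives 6400 nM.
Compound 2 `CN(C)CCn1cnnc1-c1cc(Oc2ccc(NC(=O)N/N=C/c3cccc(O)c3)cc2F)ccn1`: compound 2 gives > 100000 nM, which is a limit of the assay.
Compound 3 `CN(C)CCn1cnnc1-c1cc(Oc2ccc(NC(=O)N/N=C/c3ccc(O)c(F)c3)cc2F)ccn1`: compound 3 gives > 100000 nM, likewise a limit of the assay.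

Compound 3 therefore stands at the limit of > 100000 nM in this assay, at which 2 of the 3 values shown sit, with no number of its own. Compound 4 `CN(C)CCn1cnnc1-c1cc(Oc2ccc(NC(=O)N/N=C/c3ccc(O)cc3)cc2F)ccn1` differs from compound 3 by hydrogen in place of fluoro on an aromatic carbon. For the measured compounds named here, the measured steps give little guidance for this change: an at least 15-fold higher number from compound 1 to compound 2 (1.19 log units; beyond the scatter) and an at least 15-fold higher number from compound 1 to compound 3 (1.19 log units; beyond the scatter) both run from the one numbered compound up to the limit, and a step that the two limits leave unreadable from compound 2 to compound 3. Since both hydroxy-bearing compounds sit at the limit, compound 4 is expected to stay near where compound 3 stands, and the step of a number no higher from compound 3 to compound 4 (the limit leaves the size open) is expected to be small or not readable. Compound 4 is expected to give about 100000 nM, within 30000 nM to 300000 nM.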

Compound 4, half-maximal inhibitory concentration: 7750 nM
Compound 4: the middle estimate sits 13-fold (1.11 log units) above what was measured, outside the stated range (below it).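

In this assay, compound 2 and compound 3 each rest on a limit of the assay, not on a number: the limit of > 100000 nM in this assay, at which 2 of the 4 values shown sit.

Against that limit, the fluoro group ortho to a hydroxy group proves to matter, and so does the choice of 4-hydroxyphenyl over 3-hydroxyphenyl: an at least 12-fold lower number from compound 3 to compound 4 (1.11 log units; beyond the scatter), and an at least 12-fold lower number from compound 2 to compound 4 (1.11 log units; beyond the scatter). Compound 4 thus shows that a hydroxyphenyl compound can sit level with the 2,5-dimethoxyphenyl compound: a 1.2-fold higher number from compound 1 to compound 4 (0.08 log units; within the scatter).

On these data alone, whether a chloro or a methyl group at this place would behave like hydrogen or like fluoro stays open. As far as these compounds go, the true size of the two large steps also stays open.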